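Carbamate to Urea at the Benzylic Position

The source may hold more compounds than are shown below. What is called first, only, known or untested is meant among the compounds shown, and "the series" means these compounds.

Compound 1 `CCCC[S+]([O-])c1sc2nc(-c3nccs3)cc(-c3ccc(COC(=O)CN(C)C)cc3)c2c1N`: 3.5 nM
Compound 2 `CCCC[S+]([O-])c1sc2nc(-c3nccs3)cc(-c3ccc(COC(=O)NCC)cc3)c2c1N`: 3.4 nM

Of the compounds shown here, two have been measured in an assay for inhibition of 15-hydroxyprostaglandin dehydrogenase [NAD(+)] (Homo sapiens), read by fluorescence, with a stated time of 15 min, in the presence of a further agent that is not named here; on this read-out higher numbers stand for weaker inhibition and lower numbers for stronger inhibition. Compound 1 gives 3.5 nM and compound 2 gives 3.4 nM, and the step between them, a 1.0-fold lower number from compound 1 to compound 2 (0.01 log units; within the scatter), lies within the scatter, so neither stands apart from the other. Compound 3 `CCCC[S+]([O-])c1sc2nc(-c3nccs3)cc(-c3ccc(CNC(=O)NCC)cc3)c2c1N` differs from compound 2 by (ethylcarbamoyl)amino in place of (ethylcarbamoyl)oxy on a saturated chain carbon bound to an aromatic carbon. Going by the values given here, no measured step covers this exchange. Among the compounds with values here, the only step known, a 1.0-fold lower number from compound 1 to compound 2 (0.01 log units; within the scatter), altered the group on the carbonyl carbon without moving the number, which gives no ground to expect movement here either. For compound 3 a step of a 1.2-fold higher number from compound 2 to compound 3 (0.07 log units; within the scatter) is therefore expected, within the scatter. Compound 3 is estimated at 4 nM, with a range from 1.5 nM to 12 nM.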

Compound 3, half-maximal inhibitory concentration: 2.1 nM
For compound 3 the middle estimate is 1.9-fold (0.28 log units) above the measured one; the range from low to high includes it.
By their numbers in this assay, from the lowest: compounds 3, 2 and 1 (each within the scatter of the next).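

Putting (ethylcarbamoyl)amino in place of (ethylcarbamoyl)oxy on a saturated chain carbon bound to an aromatic carbon shows that the linking atom can also be exchanged in this assay without leaving the scatter, with a 1.6-fold lower number from compound 2 to compound 3 (0.21 log units; within the scatter). The wider exchange, from (((dimethylamino)methyl)carbonyl)oxy, likewise stays within it, with a 1.7-fold lower number from compound 1 to compound 3 (0.22 log units; within the scatter). Nothing available explains why these exchanges leave the number within the scatter.

The compounds shown leave open whether a larger change at this position would move the number. A carboxylic acid or a longer chain in place of the ethyl group would test this.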